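The source may report more compounds than this note shows. Statements on the series, on what has been measured and on what is new or still open speak of the compounds shown alone.

Four compounds share one core: compound 1 `Cc1nc(N2CCN(C)CC2)c2nc(-c3cccc(C(F)(F)F)c3)n(C3CCOCC3)c2n1`, compound 2 `Cc1nc(N2CCN(C)CC2)c2nc(-c3ccccc3F)n(C3CCOCC3)c2n1`, compound 3 `Cc1nc(N2CCN(C)CC2)c2nc(-c3ccccc3C3CC3)n(C3CCOCC3)c2n1` and the still unmeasured compound 4 `CCc1ccccc1-c1nc2c(N3CCN(C)CC3)nc(C)nc2n1C1CCOCC1`. In an ADME assay (liver) for metabolic stability, with Liver microsome (Rattus norvegicus) as the target, read by LC-MS, using microsomes, with a stated time of 30 min, tested at 4 uM (a higher number here means that more of the compound is left, a lower number that less of the compound is left), compound 1 gives 28%, compound 2 gives 30% and compound 3 gives 67%. Compound 3 therefore stands highest of the three, clear of both others. The measurements show a number 2 percentage points higher from compound 1 to compound 2 (within the scatter), but also a number 39 percentage points higher from compound 1 to compound 3 (beyond the scatter) and a number 37 percentage points higher from compound 2 to compound 3 (beyond the scatter).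

The structural change from compound 3 to compound 4 is ethyl in place of cyclopropyl on an aromatic carbon, ortho to a large group. Going by the values given here, no measured step makes this exchange, so the evidence is indirect. The closest guide is a number 37 percentage points higher from compound 2 to compound 3 (beyond the scatter), where cyclopropyl takes the place of fluoro on an aromatic carbon. The step of a number 39 percentage points higher from compound 1 to compound 3 (beyond the scatter) bears on it less directly, since it swaps the whole substituted phenyl group. Both steps are large, but neither shows how much of the higher number would survive without the three-membered ring. Ethyl still has only carbon, so a partial loss seems more likely than a full return to the level of compound 2.

The expected change is modest and downward, a number 12 percentage points lower from compound 3 to compound 4 (beyond the scatter), and it may not clear the scatter. For compound 4 the estimated value in this assay is 55%, within an expected range of 36% to 72%.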

Compound 4, percent of the compound remaining: 51%
Estimate against measurement, compound 4: 4 percentage points above, within the range that was stated.
By their numbers in this assay, from the lowest: compounds 1 and 2 (each within the scatter of the next); then compound 4; then compound 3.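

In this assay the exchange of cyclopropyl for ethyl on this aromatic carbon gives a number 16 percentage points lower from compound 3 to compound 4 (beyond the scatter) and so shows that the ring-bearing group is not interchangeable with its open-chain counterpart here, even though both groups contain only carbon. The three-membered ring is nevertheless not needed for the whole of the rise seen over fluoro, since ethyl at the same place gives a number 21 percentage points higher from compound 2 to compound 4 (beyond the scatter) and thereby places the open-chain group clear of fluoro. The wider exchange of 3-(trifluoromethyl)phenyl for 2-ethylphenyl gives a number 23 percentage points higher from compound 1 to compound 4 (beyond the scatter) as well, so a rise over compound 1 no longer depends on the 2-cyclopropylphenyl group alone.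

The compounds shown leave open how a methyl group, an isopropyl group, a methoxy group or an amine would read at this same place, and whether a longer chain such as propyl would stand nearer to ethyl or to cyclopropyl. They also offer no measurement that accounts for the differences among these groups.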